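From chloromethyl to vinyl on a piperidine amide

The source may report more compounds than this note shows. Statements on the series, on what has been measured and on what is new or still open speak of the compounds shown alone.

Measured in a functional assay on JeKo-1 cells (Homo sapiens) for inhibition, read by luminescence and CellTiter-Glo, with a stated time of 72 h; a higher number here means a weaker inhibitor, a lower number a stronger inhibitor:
compound 1 , `O=C(CCl)N1CCCC(n2nc(-c3ccc(Oc4ccccc4)cc3)cc2CO)C1`, gives 7800 nM
compound 2 , `C=CC(=O)Nc1cccc(Cn2nc(-c3ccc(Oc4ccccc4)cc3)cc2CO)c1`, gives 5200 nM
compound 3 , `CCOC(=O)c1cc(-c2ccc(Oc3ccccc3)cc2)nn1Cc1ccc(NC(=O)CCl)cc1`, gives 400 nM

Among these three, compound 1 carries the highest number. Compound 2 stands nearest, within the scatter, while compound 3 lies far lower, beyond the scatter. Compound 4 , `C=CC(=O)N1CCCC(n2nc(-c3ccc(Oc4ccccc4)cc3)cc2CO)C1`, has not yet been measured. It differs from compound 1 in one place: vinyl in place of chloromethyl on a carbonyl carbon. Among the measured compounds shown here, no measured pair differs in a single place, so the size of this step is unknown from the data. The expectation is a small shift in this assay toward a higher number, not beyond the scatter. Compound 4 is expected to give 10000 nM, between 3000 nM and 30000 nM. The expected step is a 1.3-fold higher number from compound 1 to compound 4 (0.11 log units; within the scatter), within the scatter.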

Compound 4, half-maximal inhibitory concentration: 11900 nM
Compound 4: middle estimate off by 1.2-fold (0.08 log units), on the low side; low and high end bracket the measured number.
By their numbers in this assay, from the lowest: compound 3; then compounds 2, 1 and 4 (each within the scatter of the next, the first and the last beyond it).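

In this assay, among the compounds shown here, vinyl in place of chloromethyl on a carbonyl carbon gives a 1.5-fold higher number from compound 1 to compound 4 (0.18 log units; within the scatter), the first single-place step in this set, and at this position the two groups are not told apart. Nothing available accounts for this result. The compounds shown leave open whether the same exchange would read alike on the other amides, since compound 2 and compound 3 differ from these compounds in more than one place. They also leave open what a propynyl group or a longer chain carrying a dimethylamino group would give on this carbonyl carbon.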